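Ret inhibition: amine tail variation on a shared urea core

This account rests on a few compounds, and the source may have more. Where it says the series, first, only, none or still open, it means among the compounds named here.

Measured compounds:
Compound 1 `CN(C)CCn1cnnc1-c1cc(Oc2ccc(NC(=O)Nc3ccc(Cl)c(C(F)(F)F)c3)cc2F)ccn1` gives 74.1% in an assay on isolated protein for inhibition of proto-oncogene tyrosine-protein kinase receptor Ret (Homo sapiens), read by mobility shift assay, with a stated time of 1 h, tested at 10 uM; on this read-out lower numbers stand for less inhibition and higher numbers for more inhibition at the one concentration tested (going by the name of the read-out).
Compound 2 `CCN(CC)CCn1cnnc1-c1cc(Oc2ccc(NC(=O)Nc3ccc(Cl)c(C(F)(F)F)c3)cc2F)ccn1` gives 84.4% in this assay.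
Compound 3 `CCN(CC)CCn1cnnc1-c1cc(Oc2ccc(NC(=O)Nc3ccccc3C(F)(F)F)cc2F)ccn1` gives "not determined" (no result reported) in this assay, so no number is available for it.

Compound 2 holds the highest of the two numbers; its nearest neighbour, compound 1, lies lower by a number 10.3 percentage points higher from compound 1 to compound 2 (beyond the scatter), beyond the scatter. Compound 4 `CN(C)CCCn1cnnc1-c1cc(Oc2ccc(NC(=O)Nc3ccc(Cl)c(C(F)(F)F)c3)cc2F)ccn1` differs from compound 2 in that ((dimethylamino)methyl in place of diethylamino on a saturated chain carbon, two bonds along the chain from an aromatic nitrogen). Among the compounds with values here, the one step that bears on this place on the chain is a number 10.3 percentage points higher from compound 1 to compound 2 (beyond the scatter), a modest change on going from dimethylamino to diethylamino. Compound 4 returns to a dimethylamino group but on a longer chain, so the expected step is a number 7.4 percentage points lower from compound 2 to compound 4 (within the scatter), downward and close to the scatter. Compound 4 is therefore estimated at 77%, within a range of 62% to 90%.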

Compound 4, a percentage reported as inhibition, at one concentration (the size of the read-out at that concentration, not a potency): 79.3%
For compound 4 the middle estimate is 2.3 percentage points below the measured one; measured number inside the range.
By their numbers in this assay, from the lowest: compounds 1, 4 and 2 (each within the scatter of the next, the first and the last beyond it).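

In this assay, the 3-(dimethylamino)propyl tail of compound 4 lies within the scatter of both other tails, as a number 5.2 percentage points higher from compound 1 to compound 4 (within the scatter) and a number 5.1 percentage points lower from compound 2 to compound 4 (within the scatter) show. Within the data shown here, at this place on the chain, only the pair of 2-(dimethylamino)ethyl and 2-(diethylamino)ethyl tails remains separated beyond the scatter, so compound 4 does not resolve into either side of that gap. Nothing measured here explains these numbers.

Open, going by these compounds, is whether a 3-(diethylamino)propyl tail would stand apart from compound 4 on the shared core. On these data alone, a ring amine such as morpholine at the chain end also remains untested in these data.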